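N-Ethylation of the benzenesulfonamide in the oxime series

The source may hold more compounds than are shown below. What is called first, only, known or untested is meant among the compounds shown, and "the series" means these compounds.

The series shares the core shown in compound 3 `C[n+]1ccn(CCCNS(=O)(=O)c2ccccc2)c1/C=N/O` and varies the sulfonamide arm. In a physicochemical assay for lipophilicity (on this read-out higher numbers stand for higher lipophilicity and lower numbers for lower lipophilicity), compound 3 gives -1.89, the second highest of the three numbers. Compound 2 `C[n+]1ccn(CCCNS(=O)(=O)C(F)(F)F)c1/C=N/O` gives -1.26 and compound 1 `CCN(CCCn1cc[n+](C)c1/C=N/O)S(C)(=O)=O` gives -2.69; compound 3 therefore sits below compound 2 and above compound 1, both gaps beyond the scatter.

Compound 4 `CCN(CCCn1cc[n+](C)c1/C=N/O)S(=O)(=O)c1ccccc1` differs from compound 3 by ethyl in place of hydrogen on a sulfonamide nitrogen. Going by the values given here, the only measured step, a number 0.63 log units lower from compound 2 to compound 3 (beyond the scatter), concerns the group on the sulfonyl sulfur and not the nitrogen, so it does not bear directly on this change. Among the compounds with values here, compound 1 carries an ethyl on its sulfonamide nitrogen, but it also carries methyl rather than phenyl on the sulfur, so no single-place step to it exists; its value and that of compound 3 stand apart without attribution to either change.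

Within the data shown here, with no measured precedent, the expectation rests on the change itself: replacing the nitrogen hydrogen by ethyl is expected to raise this assay by a number 0.69 log units higher from compound 3 to compound 4 (beyond the scatter). Compound 4 is thus estimated at -1.2, within a range of -1.8 to -0.6.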

Compound 4, distribution coefficient: -1.27
The estimate for compound 4 lay 0.07 log units above the measured number; the measured number falls inside the stated range.
By their numbers in this assay, from the lowest: compound 1; then compound 3; then compounds 4 and 2 (each within the scatter of the next).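

Ethyl in place of hydrogen on a sulfonamide nitrogen now has a measured step of its own: in this assay this change gives a number 0.62 log units higher from compound 3 to compound 4 (beyond the scatter) with phenyl on the sulfonyl sulfur. With ethyl held on that nitrogen, phenyl in place of methyl on a sulfonyl sulfur gives a number 1.42 log units higher from compound 1 to compound 4 (beyond the scatter) and is the larger of these two steps. Compound 1 and compound 3 differ in two places and could not be compared directly, but compound 4 now links each of them by a change in one place.

No measurement at hand accounts for the size of either step.

On these data alone, the ethyl step rests on a single pair, so its size with methyl or trifluoromethyl on the sulfonyl sulfur stays open. Also open, as far as these compounds go, is whether propyl or a longer chain on the sulfonamide nitrogen would move the number further than ethyl does, and how a chain ending in an amine or a carboxylic acid would read at this position.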